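Nitro for methoxy on the pendant phenyl ring

The compounds below may be only part of what the source reports. "The series", "measured", "known", "first", "only" and "open" are said of these compounds alone.

Of the compounds shown here, three have been measured in an ADME assay on HEL cells (Homo sapiens) for cytotoxicity, with a stated time of 3 days; a higher number here means that more compound is tolerated, a lower number that less compound is tolerated. Compound 1 `Cc1cc(-c2cccc(O)c2)c2ncc(CSCCc3ccccc3)n2c1` gives 20 ug/mL. Compound 2 `COc1cccc(-c2cc(C)c3ncc(CSCCc4ccccc4)n3c2)c1` gives 20 ug/mL, the same number as compound 1 at the digits printed, so the two stand level within the scatter. Within the data shown here, compound 3 `Cc1cc(-c2cccs2)c2ncc(CSCCc3ccccc3)n2c1` gives 100 ug/mL; the only single-point step recorded, a 5.0-fold higher number from compound 1 to compound 3 (0.70 log units; beyond the scatter), follows the exchange of the whole pendant ring and lies beyond the scatter.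

Compound 4 `Cc1cc(-c2cccc([N+](=O)[O-])c2)cn2c(CSCCc3ccccc3)cnc12` differs from compound 2 in one place: nitro in place of methoxy on an aromatic carbon. Among the measured compounds shown here, no measured step covers this exchange. For the measured compounds named here, the only step recorded concerns a change of the entire pendant ring, not of a substituent on it, and it does not bear directly on compound 4. What the numbers of compound 1 and compound 2 show is that the hydroxy and methoxy variants of the same ring give the same reading, leaving no sign that a substituent change on this ring moves this assay. On that basis the expected step is no change at the digits printed from compound 2 to compound 4 (within the scatter), that is, none beyond the scatter in either direction. Compound 4 is therefore estimated at 20 ug/mL, with a range from 10 ug/mL to 50 ug/mL.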

Compound 4, minimum cytotoxic concentration: >= 100 ug/mL
Compound 4: a limit, no number (the forecaster's own chance of this, stated with the estimate: 10%); middle value at least 5.0-fold (0.69 log units) away from the limit.
By their numbers in this assay, from the lowest: compounds 1 and 2 (each within the scatter of the next); then compound 3.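

At this place on the pendant phenyl ring, an aromatic carbon meta to a large group, a substituent change alone moves the reading in this assay: nitro in place of methoxy gives an at least 5.0-fold higher number from compound 2 to compound 4 (0.69 log units; beyond the scatter). Until now only the exchange of the whole ring had moved it, with a 5.0-fold higher number from compound 1 to compound 3 (0.70 log units; beyond the scatter), whereas on the same ring compound 1 gives 20 ug/mL and compound 2 gives 20 ug/mL, level within the scatter. The reading for compound 4 is a limit of the assay and not a number, so the step has a lower bound and no measured size: the limit of >= 100 ug/mL in this assay, at which 1 of the 4 values shown sits.

As far as these compounds go, how far compound 4 lies past its limit stays open, and with it whether compound 4 and compound 3 differ at all. Readings for an amine, a nitrile or a carboxylic acid at this same place would show whether 3-nitrophenyl stands alone among the substituted phenyl rings or whether 3-hydroxyphenyl and 3-methoxyphenyl are the exceptions.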